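Restoring the difluoromethyl, with a fluoro added

The compounds below may be only part of what the source reports. "The series", "measured", "known", "first", "only" and "open" are said of these compounds alone.

Among the measured compounds shown here, compound 2 `NS(=O)(=O)CC(=O)NCCSc1nonc1/C(=N/O)Nc1cccc(Cl)c1` gives 0.9 h in an ADME assay on isolated protein for pharmacokinetics, with UDP-glucuronosyltransferase 1A9 (Homo sapiens) as the target, read by LC-MS, with a stated time of 60 min, at 37 degrees C, tested at 1 uM, in the presence of a further agent that is not named here (a higher number here means that the compound lasts longer, a lower number that the compound disappears faster), the only plain number among the values shown. Compound 1 `NS(=O)(=O)CC(=O)NCCSc1nonc1/C(=N/O)Nc1cccc(C(F)F)c1` gives > 3 h in this assay, which is a limit of the assay rather than a number, so it sits at the limit of > 3 h in this assay, at which 1 of the 2 values shown sits. The step of an at least 3.3-fold lower number from compound 1 to compound 2 (0.52 log units; beyond the scatter) was beyond the scatter. Compound 3 `NS(=O)(=O)CC(=O)NCCSc1nonc1/C(=N/O)Nc1ccc(F)c(C(F)F)c1` carries 3-(difluoromethyl)-4-fluorophenyl in place of 3-chlorophenyl on an amine nitrogen. For the measured compounds named here, because the one measured step of an at least 3.3-fold lower number from compound 1 to compound 2 (0.52 log units; beyond the scatter) ran downward when the difluoromethyl was removed, the reverse direction is expected here, and compound 3 is expected to show a rise of a 3.3-fold higher number from compound 2 to compound 3 (0.52 log units; beyond the scatter). Compound 3 is therefore estimated at 3 h, between 1.5 h and 6 h.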

Compound 3, half-life: > 3 h
Compound 3 was reported as a limit; the forecaster's own chance of this, stated with the estimate: 50%; the middle value lies on the limit itself.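

In this assay, putting 3-(difluoromethyl)-4-fluorophenyl in place of 3-chlorophenyl on the amine nitrogen brings an at least 3.3-fold higher number from compound 2 to compound 3 (0.52 log units; beyond the scatter), so the difluoromethyl result holds with the added fluoro present. Compound 3 gives > 3 h, which is a limit of the assay and not a number. The step from compound 1 to compound 3, which adds only the fluoro, cannot be read, and the values now gather at one end: the limit of > 3 h in this assay, at which 2 of the 3 values shown sit.

As far as these compounds go, whether the fluoro changes the half-life at all stays open. So does how a trifluoromethyl or a methoxy group would compare on this ring.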